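The source may hold more compounds than are shown below. What is called first, only, known or untested is meant among the compounds shown, and "the series" means these compounds.

Compound 1 `CCn1ccc(N2C[C@H](COC)OC2=O)c1`: in an assay for inhibition of Amine oxidase [flavin-containing] B (Bos taurus), read by fluorescence, with a stated time of 30 min (on this read-out higher numbers stand for weaker inhibition and lower numbers for stronger inhibition), compound 1 gives 1300 nM.
Compound 2 `Cn1ccc(N2C[C@H](CN)OC2=O)c1`: in this assay compound 2 gives 180000 nM.

Of the two measured compounds, compound 2 stands at the higher number, that is, it is the weaker inhibitor, while compound 1 sits far lower. Compound 3 `CCn1ccc(N2C[C@H](CN)OC2=O)c1` differs from compound 2 by methyl in place of hydrogen on a saturated chain carbon bound to an aromatic nitrogen. Among the measured compounds shown here, no measured pair shows this change on its own, so its effect is not known from these data. Such a small addition is expected to move this assay only a little, possibly not beyond the scatter. The step from compound 2 to compound 3 is expected to be a 1.8-fold lower number from compound 2 to compound 3 (0.26 log units; within the scatter). Compound 3 is estimated at 100000 nM, with a range from 30000 nM to 300000 nM.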

Compound 3, inhibition constant: 25000 nM
Beside the measured number, compound 3's estimate is 4.0-fold (0.60 log units) above it; measured number below the stated range.
By their numbers in this assay, from the lowest: compound 1; then compound 3; then compound 2.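

In this assay, methyl in place of hydrogen on a saturated chain carbon bound to an aromatic nitrogen gives a 7.2-fold lower number from compound 2 to compound 3 (0.86 log units; beyond the scatter) and so counts for more than a small addition might suggest. With that ethyl group in both compounds, amino in place of methoxy on a saturated chain carbon bound to a saturated ring carbon gives a 19-fold higher number from compound 1 to compound 3 (1.28 log units; beyond the scatter) as a separate measured change. Nothing measured here gives a reason for either step. Going by these compounds, whether a longer chain, such as propyl, would lower the number further stays open. So does how a hydroxyl group would compare with amino and methoxy.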